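The source may report more compounds than this note shows. Statements on the series, on what has been measured and on what is new or still open speak of the compounds shown alone.

Measured so far:
Compound 1, `Cc1nnc(CN2CCCC2)n1-c1ccc(Cl)cc1Cc1ccccc1`: in a functional assay on the whole organism (strain CF-1) for inhibition, with Mus musculus as the target (on this read-out higher numbers stand for an effect only at larger amounts of compound and lower numbers for an effect already at smaller amounts), compound 1 gives > 100 mg/kg, which is a limit of the assay, not a number.
Compound 2, `Cc1nnc(CN(C)C)n1-c1ccc(Cl)cc1C(=O)c1ccccc1`: in this assay compound 2 gives 1.1 mg/kg.
Compound 3, `Cc1nnc(CN2CCCC2)n1-c1ccc(Cl)cc1C(=O)c1ccccc1`: in this assay compound 3 gives 2 mg/kg.

Compound 3 holds the highest of the two numbers; its nearest neighbour is compound 2, and that gap is within the usual scatter. Two measured steps lead to compound 3. The first is an at least 50-fold lower number from compound 1 to compound 3 (1.69 log units; beyond the scatter), a large change from a benzyl to a benzoyl group. The second is a 1.8-fold higher number from compound 2 to compound 3 (0.26 log units; within the scatter), a swap of the amine on the chain carbon that leaves the read-out essentially unchanged.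

Compound 4, `CNCc1nnc(C)n1-c1ccc(Cl)cc1C(=O)c1ccccc1`, differs from compound 3 in this way: methylamino in place of pyrrolidin-1-yl on a saturated chain carbon bound to an aromatic carbon. Only the second step bears on it, since it too alters the amine on the same chain carbon, and that step stayed within the scatter. A further change of the same amine is therefore expected to bring no step beyond the scatter, as a 1.3-fold lower number from compound 3 to compound 4 (0.12 log units; within the scatter) expresses. Compound 4 is thus estimated at 1.5 mg/kg in this assay, with a likely range from 0.5 mg/kg to 5 mg/kg.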

Compound 4, dose for half-maximal effect: 1.1 mg/kg
The estimate for compound 4 lay 1.4-fold (0.13 log units) above the measured number, within the range that was stated.
By their numbers in this assay, from the lowest: compounds 2, 4 and 3 (each within the scatter of the next). At a limit, above all of these: compound 1.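

The amine on the saturated chain carbon can go from the pyrrolidin-1-yl ring to the much smaller, ring-free methylamino, which adds a hydrogen-bond donor, and this assay still gives numbers within the scatter of each other (a 1.8-fold lower number from compound 3 to compound 4 (0.26 log units; within the scatter)). Trimming the dimethylamino of compound 2 to methylamino, with hydrogen in place of methyl on the amine nitrogen, also gives no separation (no change at the digits printed from compound 2 to compound 4 (within the scatter)). Among compound 2, compound 3 and compound 4, which all keep the benzoyl group, this position has so far accepted all three amines without a step beyond the scatter.

Still open, as far as these compounds go, is how the read-out behaves with an unsubstituted amine, a morpholine ring or a longer chain carrying the amine. Nothing available here explains why these three amines read alike.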